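The source may report more compounds than this note shows. Statements on the series, on what has been measured and on what is new or still open speak of the compounds shown alone.

Measured in an ADME assay on L1210/0 cells (Mus musculus) for cytotoxicity, with a stated time of 48 h; on this read-out lower numbers stand for stronger inhibition and higher numbers for weaker inhibition:
- compound 1 `Cc1ccc(-c2ncnc3c2ncn3C[C@@H]2C[C@H](CO)c3ccccc32)cc1`: 15400 nM
- compound 2 `CC1(C)[C@H](CCO)C[C@@H]1n1cnc2c(Cl)nc(N)nc21`: 105000 nM
- compound 3 `O=c1[nH]c(=O)n([C@H]2C[C@H](O)[C@@H](CO)O2)cc1/C=N/O`: 15500 nM

These three compounds do not form a series, since no two of them differ in just one place. Compound 3, at 15500 nM, lies within the usual scatter of compound 1, at 15400 nM, so the two cannot be told apart. Compound 2, at 105000 nM, has a higher number than compound 3, and that gap lies beyond the scatter.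

Compound 4 `O=c1[nH]c(=O)n([C@H]2C[C@H](O)[C@@H](CO)O2)cc1[N+](=O)[O-]` keeps the rest of compound 3 and changes one place: a group of 3 heavy atoms (1 nitrogen, 2 oxygen; no ring) in place of a group of 3 heavy atoms (1 carbon, 1 nitrogen, 1 oxygen; no ring), on an aromatic carbon. The entering group is a nitro, on an aromatic carbon. Among the measured compounds shown here, no measured step shows what such a swap does, so any expectation here is loose. Starting from compound 3 at 15500 nM, a moderate move towards a lower number is expected, though a result within the scatter remains possible. The estimated change is a 2.6-fold lower number from compound 3 to compound 4 (0.41 log units; beyond the scatter). For compound 4 the estimated value is 6000 nM, with an expected range from 1000 nM to 30000 nM.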

Compound 4, half-maximal inhibitory concentration: 130 nM
For compound 4 the middle estimate is 46-fold (1.66 log units) above the measured one; the measured number lies below the stated range.
By their numbers in this assay, from the lowest: compound 4; then compounds 1 and 3 (each within the scatter of the next); then compound 2.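

Among the compounds shown here, until this pair, no two compounds differed in just one place, so nothing showed whether this aromatic carbon mattered. In this assay, putting a nitro there gives a 120-fold lower number from compound 3 to compound 4 (2.08 log units; beyond the scatter) and shows that this single position can carry a large change, even though the leaving group and the nitro both have 3 heavy atoms and no ring, and differ in count only in having 1 hydrogen-bond donor against 0. No supporting measurement accounts for the size of this step.

Going by these compounds, with a single swap at this position, it remains open whether an amine, a nitrile or a carboxylic acid on the same carbon would give a similarly low number. On these data alone, it is also open whether a nitro would have a comparable effect on a different core.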